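Methoxy Repeated on a Larger Core: Expecting Compound 4

A few compounds are considered here, and "the series" means these few. Any claim that something is new, unique, unknown or untested is made for them only; others in the source may bear on it.

Compound 1, `Nc1nccn2cc(-c3ccccc3)nc12`, gives 12% in an assay on cells for displacement of a labelled ligand from transmembrane domain-containing protein TMIGD3 (Homo sapiens), read by scintillation counting, with a stated time of 120 min, tested at 1 uM; on this read-out higher numbers stand for more inhibition at the one concentration tested (going by the name of the read-out) and lower numbers for less inhibition.
Compound 2, `COc1ccc(-c2cn3ccnc(N)c3n2)cc1`, gives 1%.
Compound 3, `Nc1nc(-c2ccccc2)cn2cc(-c3ccccc3)nc12`, gives 23%.

These three share a core, and the unmeasured compound 4, `COc1ccc(-c2cn3cc(-c4ccccc4)nc(N)c3n2)cc1`, joins the features of compound 2 and compound 3 on that same core. Two changes are seen among the measured compounds. The first is methoxy in place of hydrogen on an aromatic carbon, and it brings a number 11 percentage points lower from compound 1 to compound 2 (beyond the scatter). The second is how the core of compound 3 differs from that of compound 1: phenyl in place of hydrogen on an aromatic carbon, which brings a number 11 percentage points higher from compound 1 to compound 3 (beyond the scatter). Compound 3 therefore stands highest of the three, its step to each of the other two lying beyond the scatter.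

Among the compounds with values here, compound 4 repeats the first change on the core of compound 3: methoxy in place of hydrogen on an aromatic carbon. The surroundings of the place are the same word for word as for the change from compound 1 to compound 2, so this is the same change, occurring twice among the compounds shown. Since the earlier instance gave a number 11 percentage points lower from compound 1 to compound 2 (beyond the scatter), a step of similar size is expected here, estimated as a number 11 percentage points lower from compound 3 to compound 4 (beyond the scatter). Whether the larger core of compound 3 alters the size of that step cannot be judged from one earlier example, so the range is kept wide. Compound 4 is accordingly expected to give about 12%, most likely between 0% and 26%.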

Compound 4, a percentage reported as inhibition, at one concentration (the size of the read-out at that concentration, not a potency): 27%
For compound 4 the middle estimate is 15 percentage points below the measured one; the measured number lies above the stated range.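

In this assay, methoxy on the phenyl of compound 3 gives a number 4 percentage points higher from compound 3 to compound 4 (within the scatter), so compound 3 and compound 4 cannot be told apart, and this step does not match the earlier one on the smaller core: the same change on two cores in this assay, a number 11 percentage points lower (beyond the scatter) from compound 1 to compound 2 and a number 4 percentage points higher (within the scatter) from compound 3 to compound 4, 15 percentage points apart, beyond the scatter of two such steps
Read the other way round, the phenyl change also depends on its surroundings, since it gives a number 26 percentage points higher from compound 2 to compound 4 (beyond the scatter), a larger step than the one seen without methoxy: the same change on two cores in this assay, a number 11 percentage points higher (beyond the scatter) from compound 1 to compound 3 and a number 26 percentage points higher (beyond the scatter) from compound 2 to compound 4, 15 percentage points apart, beyond the scatter of two such steps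
Together these show that, in this series, a step measured on one core is a poor guide to the same change on the other, but they rest on just two pairs of steps, each read at a single concentration, and they do not show why the steps differ or what would happen on any further core.

The compounds shown leave open whether other groups in the same place on the phenyl, such as a hydroxyl, a fluorine or a longer ethoxy chain, would behave like the methoxy of compound 2 or that of compound 4. They also leave open what happens when the amine on the shared core is replaced, for example by a methylamine or a hydroxyl.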